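Methylating the Second Amide Nitrogen

The compounds below may be only part of what the source reports. "The series", "measured", "known", "first", "only" and "open" are said of these compounds alone.

The compounds share one core and differ only in the substitution of their amide nitrogens. Compound 1 `O=C(N[C@H]1CN(S(=O)(=O)c2ccccc2)C[C@@H]1C(=O)N[C@H]1CCCNC1)c1cc(-c2ccccc2Cl)on1` bears hydrogen on both; in an ADME assay on cells (Hepatocyte, Rattus norvegicus) for metabolic stability (a higher number here means faster removal of the compound, a lower number slower removal), compound 1 gives 8.3 uL/min. Compound 2 `CN(C(=O)c1cc(-c2ccccc2Cl)on1)[C@H]1CN(S(=O)(=O)c2ccccc2)C[C@@H]1C(=O)N[C@H]1CCCNC1` carries a methyl group on one of the two amide nitrogens where compound 1 carries hydrogen, and in this assay compound 2 gives 12 uL/min. Compound 2 thus stands alongside compound 1 rather than apart from it, since the step of a 1.4-fold higher number from compound 1 to compound 2 (0.16 log units; within the scatter) lies within the scatter and the two values cannot be told apart.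

Compound 3 `CN(C(=O)[C@H]1CN(S(=O)(=O)c2ccccc2)C[C@@H]1N(C)C(=O)c1cc(-c2ccccc2Cl)on1)[C@H]1CCCNC1` applies the same kind of change at another amide-type nitrogen: methyl in place of hydrogen on an amide-type nitrogen. Going by the values given here, the one measured step that bears on this is a 1.4-fold higher number from compound 1 to compound 2 (0.16 log units; within the scatter), which was small and within the scatter. On that basis the expected step in this assay is likewise small, leaning if anything towards a higher number, and not beyond the scatter. Compound 3 is therefore estimated to give about 15 uL/min in this assay, with a range from 7 uL/min to 32 uL/min. The step this estimate implies is a 1.3-fold higher number from compound 2 to compound 3 (0.10 log units; within the scatter).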

Compound 3, intrinsic clearance in a liver preparation (reported as CLH), per the amount of preparation that the assay uses in the Hepatocyte assay: 13 uL/min
The estimate for compound 3 lay 1.2-fold (0.06 log units) above the measured number; measured number inside the range.
By their numbers in the Hepatocyte assay, from the lowest: compounds 1, 2 and 3 (each within the scatter of the next).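

At the amide-type nitrogen whose other neighbours are a carbonyl carbon and a saturated ring carbon, methyl in place of hydrogen gives in the Hepatocyte assay a step of a 1.1-fold higher number from compound 2 to compound 3 (0.03 log units; within the scatter), so this second methylation, like the earlier one at the other amide nitrogen, stays within the scatter. Going by these compounds alone, in a physicochemical assay for lipophilicity, measured as octanol-water partition, at pH 7.4 (on this read-out higher numbers stand for higher lipophilicity and lower numbers for lower lipophilicity), compound 2 gives 1.6 and compound 3 gives 1.6, which adds a reading the earlier compounds did not offer: the same change at this position shows no change at the digits printed from compound 2 to compound 3 (within the scatter). Nothing available gives a cause for either result.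

The compounds shown leave open whether a longer chain on this amide-type nitrogen, such as ethyl or propyl, would stay within the scatter in the Hepatocyte assay or move beyond it. Also open, going by these compounds, is whether such a chain ending in an amine or a carboxylic acid would shift the number in the physicochemical assay, where methyl in place of hydrogen left no difference to read.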